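Methylsulfanyl for chloro on the pendant aryl ring

A few compounds are considered here, and "the series" means these few. Any claim that something is new, unique, unknown or untested is made for them only; others in the source may bear on it.

Working notes on a small set around one shared core. For the measured compounds named here, compound 2, `Cn1nc(Cc2ccc(Cl)cc2)c2ccccc2c1=O`, is the only member with a numerical result: in a functional assay on aorta with Alpha-1D adrenergic receptor (Rattus norvegicus) as the target (a lower number here means that less compound is needed, a higher number that more compound is needed for the effect), compound 2 gives 430 nM, and it therefore stands alone as the sole number in the set. Compound 1, `CCCCn1nc(Cc2ccc(SC)cc2)c2ccccc2c1=O`, carries a butyl group on the core and the methylsulfanyl-bearing aryl group; in this assay compound 1 reaches only the limit > 100000 nM, which is a limit of the assay and not a number, and the limit of > 100000 nM in this assay, at which 1 of the 2 values shown sits, marks where it sits. Going by the values given here, no step between compound 1 and compound 2 is counted, so their two values are noted side by side without further reading.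

Compound 3, `CSc1ccc(Cc2nn(C)c(=O)c3ccccc23)cc1`, is not yet measured. From compound 2 it differs by methylsulfanyl in place of chloro on an aromatic carbon. Among the compounds with values here, no measured step covers this change, so the size of the expected step from compound 2 to compound 3 in this assay, a 3.5-fold higher number from compound 2 to compound 3 (0.54 log units; beyond the scatter), is set as a modest loss, and for compound 3 the estimate is 1500 nM, with a range from 300 nM to 10000 nM.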

Compound 3, half-maximal effective concentration: 930 nM
Compound 3: middle estimate off by 1.6-fold (0.21 log units), on the high side; low and high end bracket the measured number.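

On the aromatic carbon para to a large group, methylsulfanyl in place of chloro is a modest change in this assay (a 2.2-fold higher number from compound 2 to compound 3 (0.34 log units; beyond the scatter)), so this replacement keeps a measurable number on the shared core. For the compounds shown here, compound 3 also gives the first single-change reading of the chain on the aromatic nitrogen. It shares its methylsulfanyl-bearing aryl group with compound 1: hydrogen in place of propyl on a saturated chain carbon bound to that nitrogen gives a large step (an at least 100-fold lower number from compound 1 to compound 3 (2.03 log units; beyond the scatter)), well above the modest step at the aryl position. Compound 1 gives > 100000 nM, a limit of the assay and not a number, so the large step has a bound and no exact size: the limit of > 100000 nM in this assay, at which 1 of the 3 values shown sits.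

The compounds shown leave open how the number changes along the chain between the two ends seen here, for instance with an ethyl or propyl group on the aromatic nitrogen, and whether the large step also appears with chloro on the pendant ring. Also open is how a methoxy or amino group on the same aromatic carbon would read in this assay, since only chloro and methylsulfanyl are shown there.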